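This account rests on a few compounds, and the source may have more. Where it says the series, first, only, none or still open, it means among the compounds named here.

Working notes on the series. Compound 1 `Cn1nnnc1SCC(=O)N/N=C/c1ccc(Br)cc1` and compound 2 `Cn1nnnc1SCC(=O)N/N=C/c1ccc(C(F)(F)F)cc1` share one core and differ only at one aromatic carbon. In a functional assay on A549 cells (Homo sapiens) for cytotoxicity, read by XTT assay, with a stated time of 24 h (a higher number here means a weaker inhibitor, a lower number a stronger inhibitor), compound 1 gives > 10000000 nM, which is a limit of the assay and not a number. In this assay compound 2 gives 6320000 nM, the only number shown in the set. The step of an at least 1.5-fold lower number from compound 1 to compound 2 (0.19 log units; that floor lies within the scatter) is therefore bounded by the limit of > 10000000 nM in this assay, at which 1 of the 2 values shown sits, and cannot be sized beyond its floor.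

Compound 3 `Cn1nnnc1SCC(=O)N/N=C/c1ccc(O)cc1` is not yet measured. It differs from compound 2 by hydroxy in place of trifluoromethyl on an aromatic carbon. Among the compounds with values here, no measured step exchanges a trifluoromethyl for a hydroxy, and the single measured step, from a bromo to a trifluoromethyl, lies within the scatter at its floor. There is thus no basis for expecting a move in this assay beyond the scatter in either direction, and a limit rather than a number is a real possibility. Compound 3 is expected to give about 7000000 nM, within 2500000 nM to 20000000 nM, which is estimated as a step of a 1.1-fold higher number from compound 2 to compound 3 (0.04 log units; within the scatter).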

Compound 3, half-maximal inhibitory concentration: > 10000000 nM
Compound 3 ended at the assay's limit; the forecaster's own chance of this, stated with the estimate: 45%; middle value at least 1.4-fold (0.15 log units) away from the limit.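

In this assay compound 3 gives > 10000000 nM, which is a limit of the assay and not a number. Hydroxy in place of trifluoromethyl on this aromatic carbon gives an at least 1.5-fold higher number from compound 2 to compound 3 (0.19 log units; that floor lies within the scatter), so even a group with a hydrogen-bond donor and a hydrogen-bond acceptor, where trifluoromethyl has neither, produces no step at this position that can be shown to lie beyond the scatter. The step between compound 1 and compound 3 cannot be read, and with bromo, trifluoromethyl and hydroxy now tried at this position, the data do not separate the three groups, and only compound 2 has a number: the limit of > 10000000 nM in this assay, at which 2 of the 3 values shown sit.

Going by these compounds, whether an amine, a carboxylic acid or a longer chain on this aromatic carbon would give a number clearly apart from that of compound 2 remains open. Also open, on these data alone, are how far compound 1 and compound 3 truly lie from compound 2, and whether a change elsewhere on the shared core would move the values in this assay by more than the scatter.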